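Replacing the urea aryl group with a chromone amide

The compounds below may be only part of what the source reports. "The series", "measured", "known", "first", "only" and "open" are said of these compounds alone.

Of the compounds shown here, three sharing one core have been measured in a functional assay on RT-112 cells (Homo sapiens) for antiproliferative activity, read by MTT assay, with a stated time of 72 h; on this read-out lower numbers stand for stronger inhibition of growth and higher numbers for weaker inhibition of growth. Compound 1 `COc1cc(Nc2ncnc3c(NC(=O)Nc4cc(F)cc(F)c4)cccc23)cc(OC)c1` gives 2630 nM and stands as the lowest of the two numbers shown. Compound 3 `COc1cc(Nc2ncnc3c(NC(=O)Nc4ccc(Cl)c(Cl)c4)cccc23)cc(OC)c1` gives 6230 nM, a step of a 2.4-fold higher number from compound 1 to compound 3 (0.37 log units; beyond the scatter). Compound 2 `COc1cc(Nc2ncnc3c(NC(=O)Nc4ccc(Cl)c(C(F)(F)F)c4)cccc23)cc(OC)c1` reaches only a limit of the assay, > 20000 nM, and so is a limit rather than a number; this is the limit of > 20000 nM in this assay, at which 1 of the 3 values shown sits. The step of an at least 7.6-fold higher number from compound 1 to compound 2 (0.88 log units; beyond the scatter) is therefore also a limit, as is an at least 3.2-fold lower number from compound 2 to compound 3 (0.50 log units; beyond the scatter).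

Compound 4 `COc1cc(Nc2ncnc3c(NC(=O)c4cc(=O)c5ccccc5o4)cccc23)cc(OC)c1` is not yet measured in this assay. It differs from compound 1 as follows: a group of 11 heavy atoms (9 carbon, 2 oxygen; one six-membered aromatic ring of carbon only, one six-membered aromatic ring with 1 hetero atom) in place of a group of 9 heavy atoms (6 carbon, 1 nitrogen, 2 fluorine; one six-membered aromatic ring of carbon only), on a carbonyl carbon. For the measured compounds named here, no measured step changes this position in the same way; the steps from compound 1 to compound 2 and from compound 1 to compound 3 only show that exchanging the group on the amide-type nitrogen moves the number by modest amounts, and that compound 1 carries the most favourable of the three groups tried. Compound 4 is expected to show a 2.1-fold higher number from compound 1 to compound 4 (0.32 log units; beyond the scatter), with wide uncertainty. The estimate for compound 4 is 5500 nM, expected to lie between 1200 nM and 25000 nM.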

Compound 4, concentration for 50% growth inhibition: > 20000 nM
Compound 4: no number, only a limit; the forecaster's own chance of this, stated with the estimate: 25%; middle value at least 3.6-fold (0.56 log units) from the limit.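

In this assay, compound 4 gives a limit of the assay rather than a number, and it is not alone there: the limit of > 20000 nM in this assay, at which 2 of the 4 values shown sit.

The earlier steps shown here only exchanged the aryl group of the urea, whereas this change removes the whole (3,5-difluorophenyl)amino group from the carbonyl carbon and puts the group of the chromone amide there, giving an at least 7.6-fold higher number from compound 1 to compound 4 (0.88 log units; beyond the scatter). The loss also holds against the dichlorinated urea, with an at least 3.2-fold higher number from compound 3 to compound 4 (0.50 log units; beyond the scatter), so among these compounds the chromone amide does not match either urea that gives a number, while the step between compound 2 and compound 4 cannot be read, as both values are limits.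

On these data alone, how far compound 4 lies beyond the limit remains unknown, and so does the part of the loss that goes with the urea nitrogen, which takes 1 hydrogen-bond donor away, rather than with the entering ring system. A plain phenyl group on the same carbonyl carbon, or a chromone attached through a urea nitrogen, would help to separate these two changes.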